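Swapping One Group on Compound 2

The compounds below may be only part of what the source reports. "The series", "measured", "known", "first", "only" and "open" are said of these compounds alone.

In an ADME assay on L6 cells (Rattus norvegicus) for cytotoxicity, read by resazurin assay, with a stated time of 70 h (a higher number here means a weaker inhibitor, a lower number a stronger inhibitor), compound 1 `COc1cc(NC(C)CCCNC(=O)/C=C/c2cc(C(F)(F)F)cc(C(F)(F)F)c2)c2ncccc2c1` gives 83.1 ug/mL and compound 2 `COc1cc(NC(C)CCCNC(=O)Nc2cccc(O)c2)c2ncccc2c1` gives 38 ug/mL, the lower of these two numbers by a gap beyond the usual scatter between repeat measurements. Compound 3 `COc1ccc(/C(=N/NC(=O)NCCCC(C)Nc2cc(OC)cc3cccnc23)c2ccccc2)cc1` gives only a limit of the assay, > 100 ug/mL. Compound 4 `COc1cc(NC(C)CCCNC(=O)NNC(=O)Nc2ccc(Cl)cc2)c2ncccc2c1` shares its core with compound 2 but carries ((4-chlorophenyl)carbamoyl)amino in place of 3-hydroxyphenyl on an amide-type nitrogen. For the measured compounds named here, no measured pair shows this kind of swap, so no shift beyond the scatter is expected in this assay, and neither direction is favoured: the expected step is a 1.1-fold lower number from compound 2 to compound 4 (0.04 log units; within the scatter). Compound 4 is estimated at 35 ug/mL, with an expected range of 12 ug/mL to 100 ug/mL.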

Compound 4, half-maximal inhibitory concentration: 43.3 ug/mL
The estimate for compound 4 lay 1.2-fold (0.09 log units) below the measured number; the measured number falls inside the stated range.
By their numbers in this assay, from the lowest: compounds 2, 4 and 1 (each within the scatter of the next, the first and the last beyond it). At a limit, above all of these: compound 3.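

At this amide-type nitrogen, ((4-chlorophenyl)carbamoyl)amino in place of 3-hydroxyphenyl gives, in this assay, a 1.1-fold higher number from compound 2 to compound 4 (0.06 log units; within the scatter). For the compounds shown here, this is the first direct comparison at this place, and it shows that a group with more heavy atoms, a chlorine and an extra hydrogen-bond donor leaves the number within the scatter. Nothing measured here gives a reason for so small a step.

As far as these compounds go, whether an amine, a carboxylic acid or a longer chain at this nitrogen would move the number beyond the scatter stays open. So does the share of the chlorine alone, which enters together with the rest of the new group.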